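Two chain stereocentres inverted in the dimeric ester series

This account rests on a few compounds, and the source may have more. Where it says the series, first, only, none or still open, it means among the compounds named here.

Measured so far:
compound 1 `CCCC[C@H]1NC(=O)c2ccccc21`: 680000 nM
compound 2 `CCCC[C@H](OC(=O)CN1CCCC1)c1ccccc1C(=O)O[C@H]1CO[C@H]2[C@@H]1OC[C@H]2OC(=O)c1ccccc1[C@H](CCCC)OC(=O)CN1CCCC1`: 640000 nM
compound 3 `CCCC[C@H](OC(=O)CN(C)C)c1ccccc1C(=O)O[C@H]1CO[C@H]2[C@@H]1OC[C@H]2OC(=O)c1ccccc1[C@H](CCCC)OC(=O)CN(C)C`: 200000 nM

In a functional assay on cells (Platelet, Oryctolagus cuniculus) for inhibition, read by turbidimetry, with a stated time of 5 min (on this read-out higher numbers stand for weaker inhibition and lower numbers for stronger inhibition), compound 3 gives the lowest number of the three; compound 2 and compound 1 both sit above it by steps beyond the scatter. Compound 4 `CCCC[C@@H](OC(=O)CN(C)C)c1ccccc1C(=O)O[C@H]1CO[C@H]2[C@@H]1OC[C@H]2OC(=O)c1ccccc1[C@@H](CCCC)OC(=O)CN(C)C` is the next member. How it differs from compound 3: the two compounds have the same atoms and bonds and differ only in configuration as drawn: 2 of 6 stereo elements differ; a stereocentre at a saturated chain carbon is drawn S in compound 3 and R in compound 4; a stereocentre at a saturated chain carbon is drawn S in compound 3 and R in compound 4. Among the measured compounds shown here, no two measured compounds differ in a single place, so no measured step speaks to a change of configuration alone. Such a change is expected to give at most a modest step, a 2.0-fold higher number from compound 3 to compound 4 (0.30 log units; within the scatter), in the direction of weaker inhibition, if any beyond the scatter. Compound 4 is estimated at 400000 nM. For compound 4 the expected range runs from 150000 nM to 1500000 nM.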

Compound 4, half-maximal inhibitory concentration: 560000 nM
Compound 4: middle estimate off by 1.4-fold (0.15 log units), on the low side; the range from low to high includes it.
By their numbers in this assay, from the lowest: compound 3; then compounds 4, 2 and 1 (each within the scatter of the next).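

Inverting both saturated chain stereocentres from S to R gives a 2.8-fold higher number from compound 3 to compound 4 (0.45 log units; beyond the scatter), the first measured step in the series that speaks to configuration, and it runs towards weaker inhibition. The step can be assigned to configuration alone because of one fact: the fact that compounds 3 and 4 differ only in the configuration as drawn. Both centres change together, so this pair does not separate their contributions.

Open, going by these compounds, is how a compound with only one chain centre inverted would read. Also open, on these data alone, is whether a diethylamine end group in place of the dimethylamine would show a similar step on inversion.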